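A Distant Swap and the Amine's Proton

The source may report more compounds than this note shows. Statements on the series, on what has been measured and on what is new or still open speak of the compounds shown alone.

Of the compounds shown here, three have been measured in a physicochemical assay for acid dissociation. Compound 1 `COc1ccc(F)cc1CNCCCNc1ccnc2cc(Cc3cc(C)cc(C)c3)ccc12` gives 9.47, compound 2 `COc1cccc(CNCCCNc2ccnc3cc(Oc4ccc(Cl)cc4)ccc23)c1O` gives 9.28, and compound 3 `Fc1ccc(-c2ccc3c(NCCCNCc4ccco4)ccnc3c2)cc1` gives 9.47. Compound 3 stands level with compound 1 at the digits shown, and the number for compound 2 differs from that of compound 3 by an amount that lies within the usual scatter of such measurements, so the three numbers cannot be told apart with confidence.

Compound 4 `FC(F)(F)c1ccc(-c2ccc3c(NCCCNCc4ccco4)ccnc3c2)cc1` has not yet been measured. It differs from compound 3 in one place: trifluoromethyl in place of fluoro on an aromatic carbon. This change sits on the outer aromatic ring, far from the secondary amine in the linker that is the likely site of the proton being given up. Going by the values given here, with no measured pair showing the effect of this change, the expectation rests on distance alone, and the step from compound 3 to compound 4 is expected to be a number 0.02 log units lower from compound 3 to compound 4 (within the scatter), none beyond the scatter. Compound 4 is therefore expected to give 9.45, between 9.15 and 9.75.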

Compound 4, acid dissociation constant: 9.47
The estimate for compound 4 lay 0.02 log units below the measured number; the range from low to high includes it.
By their numbers in this assay, from the lowest: compounds 2, 1, 3 and 4 (each within the scatter of the next).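

In this assay, the change from 4-fluorophenyl to 4-(trifluoromethyl)phenyl gives no change at the digits printed from compound 3 to compound 4 (within the scatter). Going by these compounds alone, this is the first pair in the set that differs in one place, so it gives the first direct reading at this position: with the rest of the molecule held constant, going from the single heavy atom of fluoro to the four heavy atoms of trifluoromethyl leaves the number level. No measurement here explains why the number holds steady.

A single pair cannot show whether other groups at this position, such as an amine or a carboxylic acid, would also leave the number level. It also leaves open whether a change closer to the linker nitrogen, such as a longer chain, would shift the number beyond the scatter.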